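Methyl for chloro on the aryl ether of compound 2

The compounds below may be only part of what the source reports. "The series", "measured", "known", "first", "only" and "open" are said of these compounds alone.

Three compounds of the series have a number in an ADME assay on microsomes from liver (Rattus norvegicus) for metabolic stability, read by LC-MS, using NADPH, with a stated time of 10 min, tested at 0.5 uM (on this read-out higher numbers stand for a more stable compound and lower numbers for a less stable compound), so far. Compound 1 `CC(=O)Nc1cc(-c2cc(F)c(OC[C@@H](N)CC(C)C)c(F)c2)ccn1` gives 100% in this assay. Compound 2 `CC(=O)Nc1cc(-c2ccc(OC[C@@H](N)CC(C)C)c(Cl)c2)ccn1` gives 100% in this assay, level with compound 1 at the digits given. Compound 3 `CC(C)C[C@](C)(N)COc1cnc(-c2ccnc(Cl)c2)cc1Cl` gives 98% in this assay; the gap to compound 2 lies within the usual scatter, so the three numbers are read as one level. Going by the values given here, no pair among them differs in a single place, so no step between measured compounds can be taken from these data.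

Compound 4 `CC(=O)Nc1cc(-c2ccc(OC[C@@H](N)CC(C)C)c(C)c2)ccn1` has not been measured in this assay. It differs from compound 2 as follows: methyl in place of chloro on an aromatic carbon. The place of the exchange, on an aromatic carbon of a six-membered aromatic ring of carbon only, ortho to the (2-amino-4-methylpentyl)oxy group, is not covered by any measured pair.

Expectation: with compound 2 at 100% and no measured pair to lean on, the step from compound 2 to compound 4 in this assay is expected to stay within the scatter, a number 4 percentage points lower from compound 2 to compound 4 (within the scatter), in no fixed direction. Compound 4 is therefore estimated at 96% in this assay, with a range from 84% to 100%.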

Compound 4, percent of the compound remaining: 99%
Compound 4: middle estimate off by 3 percentage points, on the low side; low and high end bracket the measured number.
By their numbers in this assay, from the lowest: compounds 3, 4, 1 and 2 (each within the scatter of the next).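

In this assay the series now has a step in a single place, and it reads a number 1 percentage points lower from compound 2 to compound 4 (within the scatter) for methyl in place of chloro on an aromatic carbon ortho to the (2-amino-4-methylpentyl)oxy group. Going by these compounds alone, at this position, with this core, chloro and methyl therefore read as one level, which the earlier compounds could not show since no two of them differed in one place only. As compound 2 stands at 100% and compound 4 at 99% on a read-out of the percent of compound remaining, the pair sits at the top of the scale and could reveal a loss of stability but hardly a gain. Nothing available explains why the two groups read alike.

Open, as far as these compounds go, is whether a methoxy group, a nitrile, a trifluoromethyl group or a plain hydrogen on the same carbon would hold this level, since a single exchange between two groups of one heavy atom each says little about the position as a whole. Also open, from the compounds shown here alone, is whether methyl for chloro reads the same way on the core of compound 3, where a chloro group also sits on the aromatic ring bearing the ether.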